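A few compounds are considered here, and "the series" means these few. Any claim that something is new, unique, unknown or untested is made for them only; others in the source may bear on it.

Working notes on the series.

Compound 1, `COc1ccc(-n2nc(C(=O)Nc3ccc(Oc4ccnc5cc(OCCCN6CCCCC6)c(OC)cc45)c(F)c3)c(C)cc2=O)cc1`, is the reference point. In a functional assay on NCI-H460 cells (Homo sapiens) for inhibition, read by MTT assay, with a stated time of 72 h (on this read-out higher numbers stand for weaker inhibition and lower numbers for stronger inhibition), compound 1 gives 3730 nM. Compound 2, `COc1ccc(-n2nc(C(=O)Nc3ccc(Oc4ccnc5cc(OCCCN6CCC(C)CC6)c(OC)cc45)c(F)c3)c(C)cc2=O)cc1`, differs from compound 1 only by methyl in place of hydrogen on a saturated ring carbon; in this assay compound 2 gives 4650 nM, and the step of a 1.2-fold higher number from compound 1 to compound 2 (0.10 log units; within the scatter) is within the scatter, so the two numbers are treated as the same. Compound 3, `COc1cc2c(Oc3ccc(NC(=O)c4nn(-c5ccc(Cl)cc5)c(=O)cc4C)cc3F)ccnc2cc1OCCCN1CCCCC1`, carries a different core: relative to compound 1 the difference is chloro in place of methoxy on an aromatic carbon. In this assay compound 3 gives 460 nM, and the step of an 8.1-fold lower number from compound 1 to compound 3 (0.91 log units; beyond the scatter) is beyond the scatter. For the measured compounds named here, compound 3 therefore has the lowest number of the three measured so far, with compound 2 the furthest from it.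

Compound 4, `COc1cc2c(Oc3ccc(NC(=O)c4nn(-c5ccc(Cl)cc5)c(=O)cc4C)cc3F)ccnc2cc1OCCCN1CCC(C)CC1`, is not yet measured. It differs from compound 3 by methyl in place of hydrogen on a saturated ring carbon. Going by the values given here, this is the same change as the one from compound 1 to compound 2, made on the same place of the saturated ring, and on the core of compound 3 rather than that of compound 1. Among the compounds with values here, the only guide available is the measured pair, where the step of a 1.2-fold higher number from compound 1 to compound 2 (0.10 log units; within the scatter) was within the scatter. On that basis, the step of a 1.2-fold higher number from compound 3 to compound 4 (0.09 log units; within the scatter) is expected to be of the same small size, leaving compound 4 close to compound 3. For compound 4 in this assay the estimate is 560 nM, with a plausible range from 280 nM to 1200 nM. Within the data shown here, the single measured example of this change is a thin basis, so the range is kept wide.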

Compound 4, half-maximal inhibitory concentration: 370 nM
Estimate against measurement, compound 4: 1.5-fold (0.18 log units) above; the measured number falls inside the stated range.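

In this assay, the new step on the saturated ring, a 1.2-fold lower number from compound 3 to compound 4 (0.09 log units; within the scatter), is within the scatter, so 4-methylpiperidin-1-yl in place of piperidin-1-yl has no readable effect on the number on either core, and the two steps agree: the same change on two cores in this assay, a 1.2-fold higher number (0.10 log units; within the scatter) from compound 1 to compound 2 and a 1.2-fold lower number (0.09 log units; within the scatter) from compound 3 to compound 4, 1.5-fold (0.19 log units) apart, within the scatter of two such steps. The change from methoxy to chloro on the aromatic carbon also carries over with the methyl group present, where a 13-fold lower number from compound 2 to compound 4 (1.10 log units; beyond the scatter) agrees with the step measured with piperidin-1-yl: the same change on two cores in this assay, an 8.1-fold lower number (0.91 log units; beyond the scatter) from compound 1 to compound 3 and a 13-fold lower number (1.10 log units; beyond the scatter) from compound 2 to compound 4, 1.5-fold (0.19 log units) apart, within the scatter of two such steps. Within these four compounds, the two changes therefore behave as independent of each other, but this rests on one pair per comparison in this assay and does not show that either change would carry over in the same way to any other core or any other group.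

The compounds shown leave open whether a hydroxyl group or an amine in place of the methyl on the saturated ring would also leave the number where it stands on both cores. As far as these compounds go, it also remains open what a trifluoromethyl group in place of the chloro, or a longer chain leading to the saturated ring, would do to the number in this assay.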